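The source may hold more compounds than are shown below. What is called first, only, known or untested is meant among the compounds shown, and "the series" means these compounds.

Measured compounds:
compound 1 `Cc1cc(C(=O)O)nn1Cc1cc(Br)ccc1OCc1ccc(Cl)cc1` — 8.71 nM
compound 2 `Cc1cc(C(=O)O)nn1Cc1cc(Br)ccc1OCc1ccccc1Cl` — 3.16 nM
compound 3 `Cc1cc(C(=O)O)nn1Cc1cc(Br)ccc1OCc1cccc(Cl)c1` — 115 nM

In an assay on CHO-K1 cells for displacement of a labelled ligand from prostaglandin E2 receptor EP1 subtype (Homo sapiens) (a lower number here means a stronger inhibitor, a higher number a weaker inhibitor), compound 1 gives 8.71 nM, the second highest of the three numbers. Compound 2 lies closest to it, with a 2.8-fold lower number from compound 1 to compound 2 (0.44 log units; beyond the scatter), while compound 3 lies furthest away, with a 13-fold higher number from compound 1 to compound 3 (1.12 log units; beyond the scatter); between those two the gap is a 36-fold higher number from compound 2 to compound 3 (1.56 log units; beyond the scatter). Compound 4 `Cc1cc(C(=O)O)nn1Cc1cc(Br)ccc1OCc1ccc(Cl)c(C(F)(F)F)c1` has not yet been measured. It differs from compound 1 by trifluoromethyl in place of hydrogen on an aromatic carbon. Going by the values given here, no measured step adds a group at such a place; the nearest guide is the set of chloro repositionings, where the step of a 13-fold higher number from compound 1 to compound 3 (1.12 log units; beyond the scatter) shows that a chloro standing meta to the large group costs a great deal, whereas a 2.8-fold lower number from compound 1 to compound 2 (0.44 log units; beyond the scatter) shows a modest gain. Since compound 4 keeps the chloro of compound 1 and adds a trifluoromethyl ortho to it, a moderate loss in this assay is expected, estimated as a 3.4-fold higher number from compound 1 to compound 4 (0.54 log units; beyond the scatter). Compound 4 is therefore expected to give about 30 nM, within a range of 8 nM to 120 nM.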

Compound 4, half-maximal inhibitory concentration: 575 nM
The estimate for compound 4 lay 19-fold (1.28 log units) below the measured number; measured number above the stated range.
By their numbers in this assay, from the lowest: compound 2; then compound 1; then compound 3; then compound 4.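

In this assay, adding trifluoromethyl to the core of compound 1 gives a 66-fold higher number from compound 1 to compound 4 (1.82 log units; beyond the scatter), so this place, ortho to a chloro group and meta to a large group, does not accept this group without a large loss. The earlier compounds shown here had already linked a substituent at this place with a weaker result, as in a 13-fold higher number from compound 1 to compound 3 (1.12 log units; beyond the scatter), but that step also took the chloro away from its place in compound 1. Compound 4 keeps that chloro, so the loss appears with the chloro unmoved. No measurement available here accounts for the size of this step.

The compounds shown leave open whether a fluoro or a methyl group at this place would bring a similar loss. They also leave open what trifluoromethyl would do there without the chloro.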